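Indolyl replaces aminomethoxyphenyl on the shared core

The source may report more compounds than this note shows. Statements on the series, on what has been measured and on what is new or still open speak of the compounds shown alone.

Measured compounds:
Compound 1 `COc1ccc(-c2cc3nccc(-c4cc(OC)c(OC)c(OC)c4)n3n2)cc1N`: 283 nM
Compound 2 `COc1cc(-c2ccnc3cc(-c4ccc(C)cc4)nn23)cc(OC)c1OC`: 21 nM
Compound 3 `Cn1ccc2cc(-c3cc4nccc(-c5ccc(F)cc5)n4n3)ccc21`: 5210 nM

In a functional assay on HeLa cells (Homo sapiens) for inhibition, read by CCK-8 assay, with a stated time of 48 h (a higher number here means a weaker inhibitor, a lower number a stronger inhibitor), compound 1 gives 283 nM and stands second highest among the three numbers; compound 2 gives 21 nM, a clearly lower number, while compound 3 gives 5210 nM, a clearly higher one. Within the data shown here, the only single-point step recorded is a 13-fold lower number from compound 1 to compound 2 (1.13 log units; beyond the scatter), showing that exchanging the 3-amino-4-methoxyphenyl on compound 1 can move this assay by a large amount.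

Compound 4 `COc1cc(-c2ccnc3cc(-c4ccc5cc[nH]c5c4)nn23)cc(OC)c1OC` is not yet measured. It differs from compound 1 by 1H-indol-6-yl in place of 3-amino-4-methoxyphenyl on an aromatic carbon. Among the measured compounds shown here, no measured pair isolates an indolyl at this position; compound 3 carries a related bicyclic group but also a different second ring, so its high number cannot be attributed to one change. For the measured compounds named here, the one recorded step says the group here matters, but not in which direction a 1H-indol-6-yl will move this assay. Compound 4 is therefore expected near compound 1, with a wide range: a 1.1-fold lower number from compound 1 to compound 4 (0.05 log units; within the scatter) is the estimated step. The estimate for compound 4 is 250 nM, between 50 nM and 1500 nM.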

Compound 4, half-maximal inhibitory concentration: 125 nM
Beside the measured number, compound 4's estimate is 2.0-fold (0.30 log units) above it; the range from low to high includes it.
By their numbers in this assay, from the lowest: compound 2; then compound 4; then compound 1; then compound 3.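

In this assay, a 2.3-fold lower number from compound 1 to compound 4 (0.35 log units; beyond the scatter), so this aromatic carbon of the five-membered ring accepts a fused 1H-indol-6-yl in place of the single ring of 3-amino-4-methoxyphenyl without any loss, and the number even falls. The 1H-indol-6-yl still does not match the plain 4-methylphenyl, as a 6.0-fold higher number from compound 2 to compound 4 (0.77 log units; beyond the scatter), which places the three groups in a clear order at this position, with 4-methylphenyl giving the lowest number, 1H-indol-6-yl the next and 3-amino-4-methoxyphenyl the highest. Nothing available accounts for that order. 

The compounds shown leave open whether the ring hydrogen of the indole plays any part in this number, since the same position carrying an N-methylindolyl on the same core would be needed to separate it from the fused ring as such. They also leave open how a small group on the phenyl ring other than methyl, such as chloro or hydroxy, or an unsubstituted phenyl, would compare with the 4-methylphenyl of compound 2.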